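A side-group swap after three limit values

The source may report more compounds than this note shows. Statements on the series, on what has been measured and on what is new or still open speak of the compounds shown alone.

Compound 1 `CC1(C)Oc2ccc(C#N)cc2[C@@H](n2ccccc2=O)[C@]1(C)O`: > 100000 nM, a limit.
Compound 2 `CC1(C)Oc2ccc(C#N)cc2[C@@H](On2ccccc2=O)[C@]1(C)O`: > 100000 nM, a limit.
Compound 3 `CC1(C)Oc2ccc(C#N)cc2[C@@H](Nn2ccccc2=O)[C@]1(C)O`: > 100000 nM, a limit.

In a functional assay for inhibition, with Sus scrofa as the target (a lower number here means a stronger inhibitor, a higher number a weaker inhibitor), compound 3 gives only > 100000 nM, which is a limit and not a number. The series as a whole stands at the limit of > 100000 nM in this assay, at which 3 of the 3 values shown sit.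

Compound 4 `CC1(C)Oc2ccc(C#N)cc2[C@@H](OC2=CC(=O)CC2)[C@]1(C)O` changes the group on the saturated ring carbon: a group of 7 heavy atoms (5 carbon, 2 oxygen; one five-membered non-aromatic ring of carbon only) in place of a group of 8 heavy atoms (5 carbon, 2 nitrogen, 1 oxygen; one six-membered aromatic ring with 1 hetero atom), on a saturated ring carbon.

The steps at this same carbon are the nearest guide, yet none has a readable size: a step that the two limits leave unreadable from compound 1 to compound 2, a step that the two limits leave unreadable from compound 1 to compound 3 and a step that the two limits leave unreadable from compound 2 to compound 3. No clear direction can therefore be expected, and a result at the same limit seems most likely.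

The estimated step is a number no higher from compound 3 to compound 4 (the limit leaves the size open).

For compound 4 the estimate is 100000 nM, with an expected range from 30000 nM to 300000 nM.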

Compound 4, half-maximal inhibitory concentration: 20 nM
Compound 4: the middle estimate sits 5000-fold (3.70 log units) above what was measured; measured number outside the range, below it.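

In this assay, the group on this saturated ring carbon decides between activity and none, with the five-membered non-aromatic ring giving an at least 5000-fold lower number from compound 3 to compound 4 (3.69 log units; beyond the scatter) and an at least 5000-fold lower number from compound 1 to compound 4 (3.69 log units; beyond the scatter). Compound 2 already has an oxygen on this carbon, so an at least 5000-fold lower number from compound 2 to compound 4 (3.69 log units; beyond the scatter) isolates the exchange of the ring beyond that oxygen. The steps among compound 1, compound 2 and compound 3 cannot be read, and each of these compounds stays at a limit, not a number: the limit of > 100000 nM in this assay, at which 3 of the 4 values shown sit.

Going by these compounds, whether the ring's carbonyl or its double bond matters remains open. So does what a plain cyclopentyl group or an open-chain ketone would give on the same oxygen.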